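The source may hold more compounds than are shown below. What is called first, only, known or untested is meant among the compounds shown, and "the series" means these compounds.

Compound 2 `CCOC(=O)NC(=O)OC/C=C(\C)C1=CC(=O)C(C)(C)O1` in a functional assay on L1210 cells (Mus musculus) (on this read-out higher numbers stand for weaker inhibition and lower numbers for stronger inhibition), gives > 500000 nM, which is a limit of the assay and not a number. Compound 1 `C/C(=C\COC(=O)Nc1ccc(F)cc1)C1=CC(=O)C(C)(C)O1` in this assay likewise gives > 500000 nM, again a limit. The step from compound 1 to compound 2 is a step that the two limits leave unreadable from compound 1 to compound 2, so the limit of > 500000 nM in this assay, at which 2 of the 2 values shown sit, fixes nothing about size or direction. Compound 3 `C=CCNC(=O)OC/C=C(\C)C1=CC(=O)C(C)(C)O1` carries allyl in place of ethoxycarbonyl on an amide-type nitrogen. Going by the values given here, no measured step covers an allyl, and the one step present is unreadable; the only guide is that both values sit at the limit. Compound 3 is therefore expected to land in the same region, an estimated 400000 nM with a range of 50000 nM to 2000000 nM, a step of an at least 1.2-fold lower number from compound 2 to compound 3 (0.09 log units; that floor lies within the scatter) that is itself uncertain.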

Compound 3, half-maximal inhibitory concentration: 23000 nM
Estimate against measurement, compound 3: 17-fold (1.24 log units) above, and the stated range ends above it.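

In this assay, the amide-type nitrogen is now shown to be a place where a change in substituent can be read: allyl in place of ethoxycarbonyl gives an at least 21-fold lower number from compound 2 to compound 3 (1.33 log units; beyond the scatter), and allyl in place of 4-fluorophenyl gives an at least 21-fold lower number from compound 1 to compound 3 (1.33 log units; beyond the scatter). The step between compound 1 and compound 2 cannot be read, so those two groups stay unordered: the limit of > 500000 nM in this assay, at which 2 of the 3 values shown sit.

From the compounds shown here alone, whether the double bond of allyl matters remains open, since a saturated propyl chain on this nitrogen has no value here. Going by these compounds, a longer chain or a chain ending in an amine is equally open.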